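The source may report more compounds than this note shows. Statements on the series, on what has been measured and on what is new or still open speak of the compounds shown alone.

Compound 3, whose structure is `CC(C)C(CC(N)=O)c1ccc(-c2ccc3cccc(F)c3c2)[nH]c1=O`, gives 5 nM in an assay on CHO cells for displacement of a labelled ligand from prostaglandin E2 receptor EP3 subtype (Homo sapiens), read by radioligand binding; on this read-out higher numbers stand for weaker inhibition and lower numbers for stronger inhibition. Within the data shown here, this is the lowest of the three numbers measured so far, although compound 1, with structure `CC(C)NC(=O)CC(c1ccc(-c2ccc3cccc(F)c3c2)[nH]c1=O)C(C)C`, gives 5.8 nM and so lies within the scatter of compound 3. Compound 2, with structure `CC(C)C(c1ccc(-c2ccc3cccc(F)c3c2)[nH]c1=O)N1CCN/C1=N\C#N`, gives 23 nM, and a 4.6-fold lower number from compound 2 to compound 3 (0.66 log units; beyond the scatter).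

Compound 4, with structure `CC(C)C(c1cnc(N)s1)c1ccc(-c2ccc3cccc(F)c3c2)[nH]c1=O`, differs from compound 3 at one place: 2-amino-1,3-thiazol-5-yl in place of carbamoylmethyl on a saturated chain carbon bound to an aromatic carbon and a saturated chain carbon. Among the measured compounds shown here, two measured steps concern this same carbon. In the first, a 4.0-fold higher number from compound 1 to compound 2 (0.60 log units; beyond the scatter), where a five-membered non-aromatic ring took the place of an open chain. In the second, a 4.6-fold lower number from compound 2 to compound 3 (0.66 log units; beyond the scatter), where an open chain again took the place of that ring. Both show that a ring on this carbon went with weaker inhibition and its removal with stronger inhibition. The group entering in compound 4 is again a five-membered ring, this time aromatic and bearing an amino group, so the step is expected to raise the number modestly, roughly a 3.0-fold higher number from compound 3 to compound 4 (0.48 log units; beyond the scatter). Compound 4 is therefore estimated to give 15 nM in this assay, with a range from 5 nM to 45 nM.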

Compound 4, inhibition constant: 16 nM
Estimate against measurement, compound 4: 1.1-fold (0.03 log units) below, within the range that was stated.
By their numbers in this assay, from the lowest: compounds 3 and 1 (each within the scatter of the next); then compounds 4 and 2 (each within the scatter of the next).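

In this assay, putting the aromatic 2-amino-1,3-thiazol-5-yl group on this saturated chain carbon gives a 3.2-fold higher number from compound 3 to compound 4 (0.51 log units; beyond the scatter) and, measured against the longer (isopropylcarbamoyl)methyl chain, a 2.8-fold higher number from compound 1 to compound 4 (0.44 log units; beyond the scatter) so the higher number seen with the non-aromatic ring of compound 2 also appears with an aromatic ring. The two rings themselves cannot be separated, with a 1.4-fold lower number from compound 2 to compound 4 (0.16 log units; within the scatter) even though they differ in aromatic character and in their atoms. Across these four compounds, the two open amide chains therefore stand together at the lower numbers and the two five-membered rings at the higher ones, and no compound shown goes against this grouping.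

Nothing supplied alongside these numbers gives a reason for the gap between the chains and the rings. Going by these compounds, it also remains open whether a six-membered ring such as phenyl, a thiazole without its amino group, or an open chain ending in a carboxylic acid on the same carbon would fall with the rings or with the amide chains.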